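The source may report more compounds than this note shows. Statements on the series, on what has been measured and on what is new or still open speak of the compounds shown alone.

Compounds measured so far: compound 1 `CC(C)(C)c1cn(CCNc2nonc2/C(=N/O)Nc2ccc(F)c(Br)c2)nn1` gives 132 nM; compound 2 `CCC(C)(O)c1cn(CCNc2nonc2/C(=N/O)Nc2ccc(F)c(Br)c2)nn1` gives 53 nM; compound 3 `O/N=C(\Nc1ccc(F)c(Br)c1)c1nonc1NCCn1cc(C2(O)CCCCC2)nn1` gives 62 nM.

In an assay on isolated protein for inhibition of Indoleamine 2,3-dioxygenase 1 (Homo sapiens) (a higher number here means a weaker inhibitor, a lower number a stronger inhibitor), compound 3 holds the second highest of the three numbers; compound 2 lies within the scatter of it, while compound 1 is set apart by a 2.1-fold lower number from compound 1 to compound 3 (0.33 log units; beyond the scatter). Compound 4 `OCCOCc1cn(CCNc2nonc2/C(=N/O)Nc2ccc(F)c(Br)c2)nn1` differs from compound 3 by (2-hydroxyethoxy)methyl in place of 1-hydroxycyclohexyl on an aromatic carbon. Among the compounds with values here, no measured step swaps a hydroxyl-bearing group for such a chain. Within the data shown here, the steps that bear on it are a 2.5-fold lower number from compound 1 to compound 2 (0.40 log units; beyond the scatter) and a 2.1-fold lower number from compound 1 to compound 3 (0.33 log units; beyond the scatter), both seen when a hydroxyl-bearing group replaced tert-butyl, whereas a 1.2-fold higher number from compound 2 to compound 3 (0.07 log units; within the scatter) shows that exchanging one hydroxyl-bearing group for another changed little. Since compound 4 keeps a hydroxyl, only a small step is expected in this assay, a 1.3-fold higher number from compound 3 to compound 4 (0.11 log units; within the scatter), possibly none beyond the scatter. Compound 4 is therefore estimated at 80 nM, with a range from 30 nM to 220 nM.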

Compound 4, half-maximal inhibitory concentration: 28 nM
Beside the measured number, compound 4's estimate is 2.9-fold (0.46 log units) above it, and the stated range ends above it.
By their numbers in this assay, from the lowest: compounds 4, 2 and 3 (each within the scatter of the next, the first and the last beyond it); then compound 1.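

At this aromatic carbon, groups that each carry a hydroxyl are not interchangeable in this assay: (2-hydroxyethoxy)methyl in place of 1-hydroxycyclohexyl gives a 2.2-fold lower number from compound 3 to compound 4 (0.35 log units; beyond the scatter), while in place of 1-hydroxy-1-methylpropyl it gives a 1.9-fold lower number from compound 2 to compound 4 (0.28 log units; within the scatter). Its replacement of tert-butyl gives a 4.7-fold lower number from compound 1 to compound 4 (0.67 log units; beyond the scatter), the largest step at this position among the compounds shown. Nothing measured here accounts for these steps. The compounds shown leave open whether an amine, a carboxylic acid or a longer chain at this carbon would match compound 4 , and whether the ether oxygen of the chain matters at all.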